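Tert-butyl for methyl on a sulfamoyl carbamate

The source may report more compounds than this note shows. Statements on the series, on what has been measured and on what is new or still open speak of the compounds shown alone.

Measured compounds:
compound 1, `CCCCCCNS(=O)(=O)NC(=O)Nc1c(C(C)C)cccc1C(C)C`, 8100 nM
compound 2, `Cc1cc(C(C)(C)C)c(OC(=O)NS(=O)(=O)Oc2c(C(C)C)cccc2C(C)C)c(C(C)(C)C)c1`, 7700 nM
compound 3, `COc1cc(C(C)(C)C)c(OC(=O)NS(=O)(=O)Oc2c(C(C)C)cccc2C(C)C)c(C(C)(C)C)c1`, 10000 nM; 4800 nM (2 entries)

All three were tested in an assay on liver for inhibition of sterol O-acyltransferase 1 (Rattus norvegicus), using microsomes; a lower number here means a stronger inhibitor, a higher number a weaker inhibitor. Compound 2 and compound 1 sit within the scatter of each other, so the two values show no difference that can be read as an order. Compound 3 was measured more than once, and the several entries of compound 3 in this assay, 10000 nM; 4800 nM (2 entries) shows how wide the spread of repeated entries can be for one compound in this assay; its entries bracket the value of compound 2.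

Compound 4, `CC(C)c1cccc(C(C)C)c1OS(=O)(=O)NC(=O)Oc1c(C(C)(C)C)cc(C(C)(C)C)cc1C(C)(C)C`, has not yet been measured in this assay. It differs from compound 2 in one place: tert-butyl in place of methyl on an aromatic carbon. Going by the values given here, no measured pair shows the effect of such a change, so nothing here tells which way it should go. The step from compound 2 to compound 4 is expected to be a 1.0-fold higher number from compound 2 to compound 4 (0.02 log units; within the scatter), which is none beyond the scatter. Compound 4 is therefore expected to give about 8000 nM in this assay, with a likely range from 3000 nM to 25000 nM.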

Compound 4, half-maximal inhibitory concentration: 26000 nM
Compound 4: the middle estimate sits 3.3-fold (0.51 log units) below what was measured, outside the stated range (above it).
By their numbers in this assay, from the lowest: compounds 2 and 1 (each within the scatter of the next); then compound 4.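

In this assay, tert-butyl in place of methyl on this aromatic carbon, para to a large group, gives a 3.4-fold higher number from compound 2 to compound 4 (0.53 log units; beyond the scatter) and so weakens inhibition. This is the only step among the compounds shown that can be read at all, so it gives the first sign that the group at this position matters, though the effect is modest. Nothing measured here explains the loss, and its size should be weighed against how far repeated entries for one compound can lie apart: the several entries of compound 3 in this assay, 10000 nM; 4800 nM (2 entries).

The compounds shown leave open whether the loss grows gradually with the size of the group or appears only with tert-butyl. They also leave open whether an ethyl group, an amine or a carboxylic acid on this carbon would keep the number close to that of compound 2.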